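The source may hold more compounds than are shown below. What is called first, only, known or untested is meant among the compounds shown, and "the series" means these compounds.

For the measured compounds named here, compound 2 `CN1O[C@H](n2cc(-c3ccccc3)nn2)C[C@@H]1CO` is one of three compounds measured in a functional assay on 8305C cells (Homo sapiens) for cytotoxicity, read by MTT assay, with a stated time of 24 h; a lower number here means a stronger inhibitor, a higher number a weaker inhibitor; compound 2 gives 8760 nM, the highest of the three numbers. Compound 3 `CN1O[C@H](n2ccnn2)C[C@@H]1CO` gives 8130 nM and compound 1 `CN1O[C@@H](n2cc(-c3ccc(F)cc3)nn2)C[C@@H]1CO` gives 6760 nM; both stand within the scatter of compound 2. Going by the values given here, the only single-point step available, a 1.1-fold lower number from compound 2 to compound 3 (0.03 log units; within the scatter), changed nothing beyond the scatter. Compound 4 `CN1O[C@H](n2cc(-c3ccc(F)cc3)nn2)C[C@@H]1CO` differs from compound 2 by fluoro in place of hydrogen on an aromatic carbon. Compound 1 carries the same fluoro-bearing ring as compound 4 and differs from it only in the three-dimensional arrangement at one carbon; compound 1 gives 6760 nM, close to compound 2. Among the compounds with values here, no measured step points to a change beyond the scatter, so compound 4 is expected to move a 1.2-fold lower number from compound 2 to compound 4 (0.07 log units; within the scatter). The estimate for compound 4 is 7500 nM, with a range from 3500 nM to 16000 nM.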

Compound 4, half-maximal inhibitory concentration: 6850 nM
For compound 4 the middle estimate is 1.1-fold (0.04 log units) above the measured one, and the stated range covers the measured number.
By their numbers in this assay, from the lowest: compounds 1, 4, 3 and 2 (each within the scatter of the next).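

Fluoro in place of hydrogen on the aromatic carbon para to a large group gives a 1.3-fold lower number from compound 2 to compound 4 (0.11 log units; within the scatter), so this swap leaves the number in this assay unchanged within the scatter. The drawn configuration at the saturated ring carbon can also be read directly, and it gives a 1.0-fold higher number from compound 1 to compound 4 (0.01 log units; within the scatter). That reading is a clean one for a single reason: the fact that compounds 1 and 4 differ only in the configuration as drawn.

As far as these compounds go, whether an amine or a carboxylic acid on that aromatic carbon would shift the number beyond the scatter remains open. From the compounds shown here alone, the effect of changing the other stereocentre also remains open.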